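Trimming a Methyl Group: From Compound 1 to Compound 3

This account rests on a few compounds, and the source may have more. Where it says the series, first, only, none or still open, it means among the compounds named here.

Measured compounds:
compound 1, `Cc1ccc(CNC(=O)n2c(N)nc3ccccc32)cc1`: 7 nM
compound 2, `O=C(NCCCCc1ccccc1)n1cnc2ccccc21`: 2.5 nM

Both compounds were tested in an assay on HEK293 cells for inhibition of acid ceramidase (Homo sapiens), read by fluorescence, with stated times of 30 min and 1 h; on this read-out lower numbers stand for stronger inhibition and higher numbers for weaker inhibition. Compound 1 gives 7 nM, the higher of the two numbers shown. Compound 2 gives 2.5 nM, and the gap between the two lies beyond the scatter; since the two structures differ in more than one place, no single change can be read from them.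

Compound 3, `Nc1nc2ccccc2n1C(=O)NCc1ccccc1`, has not yet been measured in this assay. It differs from compound 1 by hydrogen in place of methyl on an aromatic carbon. Within the data shown here, no step between measured compounds that differ in one place is known here, so the expectation rests on compound 1 alone. The loss of a single carbon on the aromatic ring is expected to produce only a small step, if any, slightly toward a weaker number; the step of a 1.4-fold higher number from compound 1 to compound 3 (0.15 log units; within the scatter) is estimated to stay within the scatter. For compound 3 the estimate is 10 nM, with a range from 4 nM to 25 nM.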

Compound 3, half-maximal inhibitory concentration in the acid ceramidase assay: 29.3 nM
Estimate against measurement, compound 3: 2.9-fold (0.47 log units) below; measured number outside the range, above it.
By their numbers in the acid ceramidase assay, from the lowest: compound 2; then compound 1; then compound 3.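

In the acid ceramidase assay the change from 4-methylphenyl to phenyl gives a 4.2-fold higher number from compound 1 to compound 3 (0.62 log units; beyond the scatter), so a single methyl on an aromatic carbon, para to a large group, makes a difference larger than the scatter, something the earlier pair of compounds could not show. In a physicochemical assay for metabolic stability, read by HPLC, in phosphate buffer, at pH 7.4, tested at 10 uM (a higher number here means that the compound lasts longer, a lower number that the compound disappears faster), compound 1 gives 0.383 h and compound 3 gives 0.217 h; this is a 1.8-fold lower number from compound 1 to compound 3 (0.25 log units; within the scatter), so the same change leaves no readable difference on that read-out. Nothing available here accounts for either result.

The compounds shown leave open whether an ethyl group, a methoxy group or a chlorine atom at this place would match or improve on the methyl. They also leave open whether removing the methyl would cost as much on a different core or with a longer chain, such as the 4-phenylbutyl chain of compound 2.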